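This account rests on a few compounds, and the source may have more. Where it says the series, first, only, none or still open, it means among the compounds named here.

Compound 2 `CCCCCCOC(=O)c1cc(NC(=O)c2cnc(Cl)nc2C(F)(F)F)cc(C(F)(F)F)c1` carries a hexyl ester on the shared core and gives 660 nM in an assay on Jurkat cells for inhibition of cyclic AMP-dependent transcription factor ATF-1 (Homo sapiens) (a higher number here means a weaker inhibitor, a lower number a stronger inhibitor), the highest of the two numbers available; its nearest neighbour is compound 1 `CCOC(=O)c1cc(NC(=O)c2cnc(Cl)nc2C(F)(F)F)cc(C(F)(F)F)c1`, the ethyl ester, which in this assay gives 150 nM. Among the compounds with values here, the one measured step in this set, a 4.4-fold higher number from compound 1 to compound 2 (0.64 log units; beyond the scatter), shows that lengthening the ester chain was met with a modestly higher number. Compound 3 `CCCCCCCCOC(=O)c1cc(NC(=O)c2cnc(Cl)nc2C(F)(F)F)cc(C(F)(F)F)c1` extends the same chain again: ethyl in place of hydrogen on a saturated chain carbon, six bonds along the chain from an oxygen next to a carbonyl group. Within the data shown here, only that single step bears on the change, and it points toward a weaker inhibitor as the chain grows, though it spans a larger addition than the present one. A further, smaller rise beyond the scatter is therefore expected, a 2.0-fold higher number from compound 2 to compound 3 (0.29 log units; within the scatter). For compound 3 the estimated value in this assay is 1300 nM, with a range from 600 nM to 3000 nM.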

Compound 3, half-maximal inhibitory concentration: 1200 nM
The estimate for compound 3 lay 1.1-fold (0.03 log units) above the measured number; measured number inside the range.
By their numbers in this assay, from the lowest: compound 1; then compounds 2 and 3 (each within the scatter of the next).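

Placing ethyl on a saturated chain carbon, six bonds along the chain from an oxygen next to a carbonyl group, gives a 1.8-fold higher number from compound 2 to compound 3 (0.26 log units; within the scatter) in this assay, so this further extension, unlike the earlier one, produces no change that can be told apart from the usual scatter. The full change in the ester chain amounts to an 8.0-fold higher number from compound 1 to compound 3 (0.90 log units; beyond the scatter), which shows that the separation from the ethyl ester holds for both longer esters, while compound 2 and compound 3 cannot be placed in order. Nothing available here explains this behaviour.

Going by these compounds, whether a longer chain would finally move the number beyond the scatter from compound 3 remains open. So does how a branched chain, a terminal amine or a carboxylic acid in place of the ester would compare with compound 1.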